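Swapping bromine for iodine on a nucleoside transporter inhibitor

The source may hold more compounds than are shown below. What is called first, only, known or untested is meant among the compounds shown, and "the series" means these compounds.

Among the measured compounds shown here, compound 2, with structure `OC[C@H]1O[C@@H](n2cnc3c(CSc4ccc(Br)cc4)ncnc32)[C@H](O)[C@@H]1O`, has the lowest of the two numbers measured so far: in an assay on isolated protein for binding affinity to Equilibrative nucleoside transporter 1 (Homo sapiens) (on this read-out lower numbers stand for stronger inhibition and higher numbers for weaker inhibition), compound 2 gives 178 nM. Its nearest neighbour is compound 1, structure `OC[C@H]1O[C@@H](n2cnc3c(CSc4c(F)cccc4Cl)ncnc32)[C@H](O)[C@@H]1O`, which in this assay gives 1510 nM; the step of an 8.5-fold lower number from compound 1 to compound 2 (0.93 log units; beyond the scatter) lies beyond the scatter. Compound 3, structure `OC[C@H]1O[C@@H](n2cnc3c(CSc4ccc(I)cc4)ncnc32)[C@H](O)[C@@H]1O`, has not yet been measured. The change from compound 2 to compound 3 is iodo in place of bromo on an aromatic carbon. For the measured compounds named here, the only measured step exchanged the whole aryl group, not one halogen for another, so no measured step speaks directly to this change, and it gives no clue of direction. A halogen swap at one aromatic carbon is therefore expected to give a step within the scatter, a 1.1-fold lower number from compound 2 to compound 3 (0.05 log units; within the scatter). For compound 3 the estimate in this assay is 160 nM, with a range from 60 nM to 420 nM.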

Compound 3, half-maximal inhibitory concentration: 69.2 nM
The estimate for compound 3 lay 2.3-fold (0.36 log units) above the measured number, within the range that was stated.
By their numbers in this assay, from the lowest: compound 3; then compound 2; then compound 1.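

In this assay, exchanging bromo for iodo gives a 2.6-fold lower number from compound 2 to compound 3 (0.41 log units; beyond the scatter), so one halogen atom on this aromatic carbon, para to a large group, is enough to move the number beyond the scatter. The earlier step could not show this, as it exchanged the whole aryl group and left the effect of the atom at this place unknown. With the 4-iodophenyl group, the exchange of the whole aryl group becomes a 22-fold lower number from compound 1 to compound 3 (1.34 log units; beyond the scatter), and compound 3 now has the lowest number of the three. Nothing available here explains why iodo gives the lower number.

As far as these compounds go, two halogens are too few to set a trend, so it remains open how a 4-chlorophenyl group or an amine on the same aromatic carbon would compare. From the compounds shown here alone, it is also open whether iodo would give a lower number than bromo with an oxygen in place of the sulfur.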